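The source may report more compounds than this note shows. Statements on the series, on what has been measured and on what is new or still open speak of the compounds shown alone.

In an ADME assay on cells (Homo sapiens) for cytotoxicity, read by polymerase chain reaction, with a stated time of 3 days (a higher number here means that more compound is tolerated, a lower number that less compound is tolerated), the measured compounds stand as follows. Compound 1 `Cc1nc(N(C)C)nc(N[C@@H]2C[C@H](CO)[C@@H](O)[C@H]2O)c1-c1nc2ccccc2s1` gives 18000 nM. Compound 2 `Cc1nc(NCCOC(C)C)nc(N[C@@H]2C[C@H](CO)[C@@H](O)[C@H]2O)c1-c1nc2ccccc2s1` gives 8000 nM. Compound 3 `Cc1nc(Nc2ncco2)nc(N[C@@H]2C[C@H](CO)[C@@H](O)[C@H]2O)c1-c1nc2ccccc2s1` gives only a limit, > 25000 nM.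

Compound 3 therefore has no exact number, only (the limit of > 25000 nM in this assay, at which 1 of the 3 values shown sits). Compound 4 `Cc1nc(NCc2ccccn2)nc(N[C@@H]2C[C@H](CO)[C@@H](O)[C@H]2O)c1-c1nc2ccccc2s1` differs from it in one place: (pyridin-2-yl)methyl in place of 1,3-oxazol-2-yl on a nitrogen on an aromatic ring. The measured steps that touch this position are a 2.3-fold lower number from compound 1 to compound 2 (0.35 log units; beyond the scatter), an at least 1.3-fold higher number from compound 1 to compound 3 (0.14 log units; that floor lies within the scatter) and an at least 3.1-fold higher number from compound 2 to compound 3 (0.49 log units; beyond the scatter); they show that a chain-bearing substituent on this nitrogen gave the lowest number, while the oxazolyl gave the highest. Compound 4 is expected to sit between these, at about 15000 nM, within 5000 nM to 40000 nM. The expected step is an at least 1.6-fold lower number from compound 3 to compound 4 (0.22 log units; that floor lies within the scatter).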

Compound 4, half-maximal cytotoxic concentration: 13000 nM
Compound 4: the middle estimate sits 1.2-fold (0.06 log units) above what was measured; measured number inside the range.
By their numbers in this assay, from the lowest: compounds 2, 4 and 1 (each within the scatter of the next, the first and the last beyond it). At a limit, above all of these: compound 3.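

Placing (pyridin-2-yl)methyl on this nitrogen gives a 1.6-fold higher number from compound 2 to compound 4 (0.21 log units; within the scatter) and a 1.4-fold lower number from compound 1 to compound 4 (0.14 log units; within the scatter), so an aromatic ring on a one-carbon link does not clearly separate this compound from those with the dimethylamino or 2-isopropoxyethyl groups. Against the oxazolyl group the change gives an at least 1.9-fold lower number from compound 3 to compound 4 (0.28 log units; that floor lies within the scatter), which leaves the size of that drop unsettled. Compound 3 stands only at a limit, so this step has a floor and no exact size: the limit of > 25000 nM in this assay, at which 1 of the 4 values shown sits.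

Still open, from the compounds shown here alone, is how a benzyl group, or a pyridin-2-yl group set directly on the nitrogen, would compare with compound 3 and compound 4.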